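The source may report more compounds than this note shows. Statements on the series, on what has been measured and on what is new or still open speak of the compounds shown alone.

The measured compounds:
Compound 1 `C[Se]/C(=N\C(=O)c1cc2ccccc2s1)NC(=O)c1cc2ccccc2s1` gives 94000 nM in a functional assay on PC-3 cells (Homo sapiens) for cytotoxicity, read by MTT assay, with a stated time of 72 h; a higher number here means that more compound is tolerated, a lower number that less compound is tolerated.
Compound 2 `CS/C(=N\C(=O)c1cc2ccccc2s1)NC(=O)c1cc2ccccc2s1` gives 72600 nM in this assay.
Compound 3 `C[Se]/C(=N\C(=O)c1cc(-c2ccccc2)nc2ccccc12)NC(=O)c1cc(-c2ccccc2)nc2ccccc12` reaches only a limit of this assay, > 100000 nM.

For the measured compounds named here, of the two plain numbers, compound 2 holds the lower one, but the single measured step, a 1.3-fold lower number from compound 1 to compound 2 (0.11 log units; within the scatter), stays within the scatter, so the two compounds cannot be told apart. That step exchanges selenium for sulfur in the small group on the carbon with a double bond to nitrogen and changes little. The value of compound 3 is a limit and gives no number to compare.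

Compound 4 `O=C(/N=C(/NC(=O)c1cc2ccccc2s1)[Se]Cc1ccccc1)c1cc2ccccc2s1` has not been measured. It differs from compound 2 by a group of 8 heavy atoms (7 carbon, 1 selenium; one six-membered aromatic ring of carbon only) in place of a group of 2 heavy atoms (1 carbon, 1 sulfur; no ring), on a carbon with a double bond to nitrogen. Going by the values given here, the step from compound 1 to compound 2 shows that the sulfur-selenium exchange at this place barely matters; no measured step covers the addition of the six-membered aromatic ring there. The step from compound 2 to compound 4 is therefore expected to be small, around a 1.5-fold lower number from compound 2 to compound 4 (0.16 log units; within the scatter), and not clearly beyond the scatter. Compound 4 is estimated at 50000 nM, with a likely range from 15000 nM to 150000 nM.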

Compound 4, concentration lethal to 50% of the cells: 86300 nM
The estimate for compound 4 lay 1.7-fold (0.24 log units) below the measured number, within the range that was stated.
By their numbers in this assay, from the lowest: compounds 2, 4 and 1 (each within the scatter of the next). At a limit, above all of these: compound 3.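

Placing a selenium-linked group with a six-membered aromatic ring on the carbon with a double bond to nitrogen, where methylsulfanyl stood, brings no readable change in this assay: a 1.2-fold higher number from compound 2 to compound 4 (0.08 log units; within the scatter). Phenyl in place of hydrogen on the saturated chain carbon bound to selenium, the one change separating this pair, also stays unresolved, a 1.1-fold lower number from compound 1 to compound 4 (0.04 log units; within the scatter), so among these compounds this place accepts a far bulkier group without a readable shift in the number. Compound 3 alone gives no plain number, only a limit: the limit of > 100000 nM in this assay, at which 1 of the 4 values shown sits.

As far as these compounds go, whether an amine, a carboxylic acid or a longer chain on the selenium would move the number beyond the scatter stays open. So does the effect of a phenyl ring carrying a chlorine or methoxy group.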